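Hydrogen in place of methyl on an aromatic carbon

The source may hold more compounds than are shown below. What is called first, only, known or untested is meant among the compounds shown, and "the series" means these compounds.

In a physicochemical assay for lipophilicity, read by HPLC, in phosphate buffer, measured as octanol-water partition, with a stated time of 1 h, at pH 7.4 (on this read-out lower numbers stand for lower lipophilicity and higher numbers for higher lipophilicity), compound 2 `Cc1cc(C#N)cnc1C(=O)Nc1ccc(F)c([C@]2(C)C=C(CF)OC(N)=N2)c1` gives 2.5 and compound 1 `CC1=C[C@@](C)(c2cc(NC(=O)c3ccc(C#N)cn3)ccc2F)N=C(N)O1` gives 2.2. Among the measured compounds shown here, these are the only two numbers so far, and they lie within the usual scatter of each other, so compound 2 stands level with compound 1 on present evidence. Compound 3 `C[C@@]1(c2cc(NC(=O)c3ccc(C#N)cn3)ccc2F)C=C(CF)OC(N)=N1` is reached from compound 2 by hydrogen in place of methyl on an aromatic carbon, turning 5-cyano-3-methylpyridin-2-yl into 5-cyanopyridin-2-yl. For the measured compounds named here, compound 1 and compound 2 differ in more than one place, so no measured pair isolates this change. Compound 1 does carry the 5-cyanopyridin-2-yl group, and its 2.2 is the nearest guide. A small step towards lower numbers is expected in this assay, close to the edge of the scatter. The expected size is a number 0.30 log units lower from compound 2 to compound 3 (within the scatter). For compound 3 the estimate is 2.2, with an expected range of 1.9 to 2.5.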

Compound 3, distribution coefficient: 2.3
Estimate against measurement, compound 3: 0.10 log units below, within the range that was stated.
By their numbers in this assay, from the lowest: compounds 1, 3 and 2 (each within the scatter of the next).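

In this assay, among the compounds shown here, turning 5-cyano-3-methylpyridin-2-yl into 5-cyanopyridin-2-yl gives a number 0.20 log units lower from compound 2 to compound 3 (within the scatter), the first reading that isolates this methyl, so the change at this aromatic carbon, ortho to a large group, stays inside the scatter. Fluoro in place of hydrogen on the saturated chain carbon bound to a double-bonded ring carbon gives a number 0.10 log units higher from compound 1 to compound 3 (within the scatter), so this single change also stays inside the scatter in this assay. No other measurement accompanies these steps to account for them.

On these data alone, what a methoxy group or an amine on this aromatic carbon would give in this assay stays open. As far as these compounds go, each change is seen here in a single pair, so whether either step repeats on a different core also stays open.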